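Chloro on the benzyl ring of a sulfonylguanidine

This account rests on a few compounds, and the source may have more. Where it says the series, first, only, none or still open, it means among the compounds named here.

Measured: compound 1 `C/C(C#Cc1ccccc1)=N\N/C(N)=N/S(=O)(=O)c1cc(C)c(Cl)cc1SCc1ccccc1` with 38000 nM in an ADME assay on HaCaT cells (Homo sapiens) for cytotoxicity, read by MTT assay, with a stated time of 72 h; a higher number here means a weaker inhibitor, a lower number a stronger inhibitor; compound 2 `C/C(C#Cc1ccccc1)=N\N/C(N)=N/S(=O)(=O)c1cc(C)c(Cl)cc1SCc1cccc(C)c1` with "not determined" (no result reported) in this assay.

Compound 1 thus stands on the only number shown, and it is a weak inhibitor there. Compound 3 `C/C(C#Cc1ccccc1)=N\N/C(N)=N/S(=O)(=O)c1cc(C)c(Cl)cc1SCc1cccc(Cl)c1` differs from compound 1 by chloro in place of hydrogen on an aromatic carbon. Within the data shown here, no step between measured compounds is known, so nothing here argues for a change beyond the scatter of this assay in either direction. Compound 3 is therefore expected to give about 30000 nM, with a range from 12000 nM to 80000 nM, a step of a 1.3-fold lower number from compound 1 to compound 3 (0.10 log units; within the scatter) that is estimated to stay within the scatter.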

Compound 3, half-maximal inhibitory concentration: 155000 nM
Estimate against measurement, compound 3: 5.2-fold (0.71 log units) below; measured number above the stated range.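

In this assay, replacing hydrogen with chloro to turn benzyl into 3-chlorobenzyl gives a 4.1-fold higher number from compound 1 to compound 3 (0.61 log units; beyond the scatter) and so makes compound 3 the weaker inhibitor. The result shows that the number responds to a single chlorine atom at this place on the aromatic ring. No measurement shown accounts for the size or direction of this step.

The step involving compound 2 cannot be read, as it has no number. From the compounds shown here alone, whether a fluoro, a methoxy or an amine at the same place would shift the number in the same direction remains open.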